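Removing a Fluorine from Compound 2: Expectation for Compound 4

The source may report more compounds than this note shows. Statements on the series, on what has been measured and on what is new or still open speak of the compounds shown alone.

Measured so far:
compound 1 `O=C(NO)c1ccc(NCc2nc(-c3cccs3)nn2-c2ccc(O)cc2)cc1` — 33.5 nM
compound 2 `O=C(NO)c1ccc(NCc2nc(-c3ccc(F)cc3)nn2-c2ccccc2)cc1` — 115 nM
compound 3 `Cc1ccsc1-c1nc(CNc2ccc(C(=O)NO)cc2)n(-c2ccccc2)n1` — 30.7 nM

All three share a core built around a hydroxamic acid, and all were tested in an assay on Sf9 cells for inhibition of protein deacetylase HDAC6 (Homo sapiens), read by fluorescence, with a stated time of 40 min; on this read-out higher numbers stand for weaker inhibition and lower numbers for stronger inhibition. Among them compound 2 stands at the highest number, meaning the weakest inhibition; the nearest is compound 1, and the furthest is compound 3, and both gaps lie beyond the scatter.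

Compound 4 `O=C(NO)c1ccc(NCc2nc(-c3ccccc3)nn2-c2ccccc2)cc1` has not yet been measured. It differs from compound 2 in one place: hydrogen in place of fluoro on an aromatic carbon. For the measured compounds named here, only one measured step touches the same ring. That step, a 3.7-fold lower number from compound 2 to compound 3 (0.57 log units; beyond the scatter), swaps the whole 4-fluorophenyl for a 3-methylthiophen-2-yl, a much larger change than simply taking away the fluoro. Going by the values given here, no measured pair isolates the fluoro alone, so the best guide is that altering this ring can shift the number modestly, while a change of a single atom is likely to matter less. In this assay compound 4 is therefore expected to sit close to compound 2, with the estimated step of a 1.2-fold lower number from compound 2 to compound 4 (0.08 log units; within the scatter) probably within or only just beyond the scatter. The expected value for compound 4 is 95 nM, in a range from 35 nM to 250 nM.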

Compound 4, half-maximal inhibitory concentration: 112 nM
For compound 4 the middle estimate is 1.2-fold (0.07 log units) below the measured one, within the range that was stated.
By their numbers in this assay, from the lowest: compounds 3 and 1 (each within the scatter of the next); then compounds 4 and 2 (each within the scatter of the next).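

In this assay hydrogen in place of fluoro, on an aromatic carbon para to a large group, gives a 1.0-fold lower number from compound 2 to compound 4 (0.01 log units; within the scatter) and so shows no readable effect of this single atom at this position. The gap to the thiophene compound remains once the fluoro is gone: phenyl in place of 3-methylthiophen-2-yl gives a 3.6-fold higher number from compound 3 to compound 4 (0.56 log units; beyond the scatter) and shows that this larger change to the ring moves the number even though removing the fluoro does not. Nothing at hand explains why these two ring changes differ in this way.

On these data alone, it remains open whether a group larger than fluoro in the same place, such as methoxy, an amine or a carboxylic acid, would also leave the number unmoved. The role of the methyl on the thiophene is also unsettled: compound 1 carries a thiophen-2-yl without that methyl, yet it differs from compound 3 in a second place as well, so this pair cannot isolate the methyl.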